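Terminal methoxy removal on the aminophenyl thioether

This account rests on a few compounds, and the source may have more. Where it says the series, first, only, none or still open, it means among the compounds named here.

Compound 1 `COc1ccc(CCCCCCCCOc2ccc(CSc3cccc(N)c3)nc2/C=C/C(=O)O)cc1` gives 34 nM in an assay for binding affinity to leukotriene B4 receptor 1 (Homo sapiens); on this read-out higher numbers stand for weaker inhibition and lower numbers for stronger inhibition. Compound 2 `COc1ccc(CCCCCCCCOc2ccc(CSc3cccc(OC)c3)nc2/C=C/C(=O)O)cc1` gives 192 nM and compound 3 `COc1ccc(CCCCCCCCOc2ccc(CSc3ccccc3)nc2/C=C/C(=O)O)cc1` gives 74 nM. The cores of compound 2 and compound 1 differ by amino in place of methoxy on an aromatic carbon; read the other way round, this is a step of a 5.6-fold higher number from compound 1 to compound 2 (0.75 log units; beyond the scatter). Compound 4 `Nc1cccc(SCc2ccc(OCCCCCCCCc3ccccc3)c(/C=C/C(=O)O)n2)c1` is not yet measured.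

The change from compound 1 to compound 4 is hydrogen in place of methoxy on an aromatic carbon. The same kind of change, (hydrogen in place of methoxy on an aromatic carbon), made a step of a 2.6-fold lower number from compound 2 to compound 3 (0.41 log units; beyond the scatter). The place is not the same: in the measured pair the group sits meta to a large group, in the new pair para to a large group, and on a different ring of the molecule.

For compound 4 a step of a 1.2-fold higher number from compound 1 to compound 4 (0.07 log units; within the scatter) in this assay is expected, resting on the measured removal at compound 2 to compound 3 a 2.6-fold lower number from compound 2 to compound 3 (0.41 log units; beyond the scatter), tempered by the different place, so a number close to that of compound 1 34 nM is expected.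

Compound 4 is estimated at 40 nM, between 12 nM and 130 nM.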

Compound 4, inhibition constant: 36 nM
Compound 4: middle estimate off by 1.1-fold (0.05 log units), on the high side; low and high end bracket the measured number.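

In this assay, the 4-methoxyphenyl to phenyl change on the core of compound 1 gives a 1.1-fold higher number from compound 1 to compound 4 (0.02 log units; within the scatter), so at this place the methoxy can be replaced by hydrogen with no change that stands out from the scatter. Set beside the earlier removal, the same written change does not carry over as a step of one size: the same change on two cores in this assay, a 2.6-fold lower number (0.41 log units; beyond the scatter) from compound 2 to compound 3 and a 1.1-fold higher number (0.02 log units; within the scatter) from compound 1 to compound 4, 2.7-fold (0.44 log units) apart, beyond the scatter of two such steps The two removals differ in both the core and the place of the group, and these pairs cannot separate the two, leaving no general rule for this change in the series.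

Open, going by these compounds, is whether the amino group still matters on the core of compound 4 as it does in a 2.2-fold higher number from compound 1 to compound 3 (0.34 log units; beyond the scatter), a question that a compound with neither amino nor methoxy would address. Also open, on these data alone, is how a fluorine or a hydroxyl para to a large group on the terminal phenyl, or a shorter chain, would read in this assay.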